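The compounds below may be only part of what the source reports. "The series", "measured", "known", "first", "only" and "open" are said of these compounds alone.

Measured compounds:
Compound 1 `Cc1cc(C)c(CN2CCc3ccc(O[C@@H]4CCOC4)c(Cl)c3C2=O)c(=O)[nH]1` gives 28 nM in an assay on Sf9 cells for inhibition of histone-lysine N-methyltransferase EZH2 (Homo sapiens), read by scintillation counting, with a stated time of 60 min, in the presence of a further agent that is not named here; on this read-out higher numbers stand for weaker inhibition and lower numbers for stronger inhibition.
Compound 2 `Cc1cc(C)c(CN2CCc3ccc(-c4c(C)noc4C)c(Cl)c3C2=O)c(=O)[nH]1` gives 3.2 nM in this assay.
Compound 3 `Cc1cc(C)c(CN2CCc3ccc(OC(C)C)c(Cl)c3C2=O)c(=O)[nH]1` gives 41 nM in this assay.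

Compound 1 stands second highest of the three numbers. Its nearest neighbour is compound 3, a step of a 1.5-fold higher number from compound 1 to compound 3 (0.17 log units; within the scatter), which is a change of the group on the oxygen of the shared core. The furthest is compound 2: the step of an 8.8-fold lower number from compound 1 to compound 2 (0.94 log units; beyond the scatter) is the only one beyond the scatter and follows from swapping the ether for the 3,5-dimethyl-1,2-oxazol-4-yl group; the reverse exchange is seen in a 13-fold higher number from compound 2 to compound 3 (1.11 log units; beyond the scatter).

Compound 4 `Cc1cc(C)c(CN2CCc3c(C)cc(O[C@@H]4CCOC4)c(Cl)c3C2=O)c(=O)[nH]1` is not yet measured. It differs from compound 1 by methyl in place of hydrogen on an aromatic carbon. For the measured compounds named here, every measured step concerns the group on the oxygen or the aromatic carbon carrying it, so none bears directly on this position, and no measured pair shows what a methyl here does. With no guide, the expectation is a step of a 1.3-fold lower number from compound 1 to compound 4 (0.10 log units; within the scatter), that is, no change beyond the scatter. Compound 4 is therefore estimated at 22 nM in this assay, within a range from 7 nM to 70 nM.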

Compound 4, half-maximal inhibitory concentration: 18 nM
Estimate against measurement, compound 4: 1.2-fold (0.09 log units) above; the range from low to high includes it.
By their numbers in this assay, from the lowest: compound 2; then compounds 4, 1 and 3 (each within the scatter of the next, the first and the last beyond it).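

Methyl in place of hydrogen on this aromatic carbon, which is ortho to a fused ring and para to a chloro group, gives a 1.6-fold lower number from compound 1 to compound 4 (0.19 log units; within the scatter). For the compounds shown here, this is the first view of this position, as the earlier compounds differ only in the group on the oxygen or in the group on the aromatic carbon carrying it; here, one added carbon atom leaves the number in this assay within the scatter of the number for compound 1, so a methyl is accepted at this place with the (oxolan-3-yl)oxy group kept. Nothing measured here gives a reason for this result.

The compounds shown leave open whether the same methyl would also stay within the scatter when paired with the 3,5-dimethyl-1,2-oxazol-4-yl group of compound 2 or the isopropoxy group of compound 3. They also leave open what a different group on this carbon would do, such as an ethyl, a methoxy group or an amine, as a single methyl says nothing about any of these.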